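Shortening the Hydroxyalkyl Chain: Compound 1 to Compound 4

The source may report more compounds than this note shows. Statements on the series, on what has been measured and on what is new or still open speak of the compounds shown alone.

Compound 1, `Cn1ncc(Cl)c1-c1cc(C(=O)N[C@@H]2CN[C@H](CCCO)C[C@H]2c2ccc(Cl)c(Cl)c2)oc1Cl`: 600 nM
Compound 2, `Cn1ncc(Cl)c1-c1cc(C(=O)N[C@@H]2CNCC[C@H]2c2ccc(C(F)(F)F)cc2)oc1Cl`: 120 nM
Compound 3, `O=C(N[C@@H]1CNCC[C@H]1c1ccc(Cl)cc1)c1ccc(-c2ncnc3c2CCC3O)s1`: 24100 nM

Of the compounds shown here, three have been measured in a functional assay on OVCAR-8 cells (Homo sapiens) for antiproliferative activity; a higher number here means a weaker inhibitor, a lower number a stronger inhibitor. Compound 1 stands at the second highest of the three numbers. Its nearest neighbour is compound 2, whose number is lower by a gap beyond the usual scatter, so compound 2 is the stronger inhibitor of the pair. Compound 3 lies far higher, again beyond the scatter, and is the weakest of the three in this assay.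

Compound 4, `Cn1ncc(Cl)c1-c1cc(C(=O)N[C@@H]2CN[C@H](CCO)C[C@H]2c2ccc(Cl)c(Cl)c2)oc1Cl`, has not yet been measured. It differs from compound 1 in one place: hydroxy in place of hydroxymethyl on a saturated chain carbon, two bonds along the chain from a saturated ring carbon. Within the data shown here, no measured pair shows this particular change, so any expectation rests on compound 1 alone. The shortening of the chain by one carbon is a modest alteration at a remote position, and the step from compound 1 to compound 4 is expected to be small, with no direction beyond the scatter, because compound 1 gives 600 nM and nothing in the measured set argues for a shift. Compound 4 is therefore expected to give about 550 nM, with a range from 200 nM to 1500 nM. This estimate corresponds to an expected step of a 1.1-fold lower number from compound 1 to compound 4 (0.04 log units; within the scatter).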

Compound 4, half-maximal inhibitory concentration: 610 nM
Estimate against measurement, compound 4: 1.1-fold (0.04 log units) below; the range from low to high includes it.
By their numbers in this assay, from the lowest: compound 2; then compounds 1 and 4 (each within the scatter of the next); then compound 3.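

In this assay, among these compounds, the change from 3-hydroxypropyl to 2-hydroxyethyl gives a 1.0-fold higher number from compound 1 to compound 4 (0.01 log units; within the scatter), the first step in this set that isolates this chain. Removing this one carbon therefore leaves the read-out unresolved from that of the longer chain, so this assay does not separate these two chain lengths on the core of compound 1. No supporting data bear on the reason for this result.

The compounds shown leave open whether this insensitivity extends to a shorter hydroxymethyl chain, a longer 4-hydroxybutyl chain, or a chain ending in an amine or a carboxylic acid. They also leave open how a hydrogen at this position would compare with either hydroxyalkyl chain on an otherwise identical core.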